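Aryl-piperazine dithiocarbamates: methoxy to cyano on the aryl

The source may report more compounds than this note shows. Statements on the series, on what has been measured and on what is new or still open speak of the compounds shown alone.

Measured compounds:
compound 1 `Nc1ccccc1NC(=O)c1ccc(CSC(=S)N2CCCc3ccccc32)cc1` gives 38.5%
compound 2 `COc1ccc(N2CCN(C(=S)SCc3ccc(C(=O)Nc4ccccc4N)cc3)CC2)cc1` gives 25.3%
compound 3 `Nc1ccccc1NC(=O)c1ccc(CSC(=S)N2CCCC2)cc1` gives 27%

All three numbers come from a functional assay on MGC-803 cells (Homo sapiens) for antiproliferative activity, read by CCK-8 assay, with a stated time of 72 h, tested at 2 uM; a higher number here means a stronger effect of the compound at the concentration tested, a lower number a weaker effect. Compound 2 holds the smallest of the three; its gap to compound 3 lies within the scatter, so no order between those two is claimed, while compound 1 stands beyond the scatter above it. Within the data shown here, the one step that can be read between measured compounds is a number 11.5 percentage points lower from compound 1 to compound 3 (beyond the scatter); it changes the amine on the thiocarbonyl carbon and leaves the rest of the shared core untouched.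

Compound 4 `N#Cc1ccc(N2CCN(C(=S)SCc3ccc(C(=O)Nc4ccccc4N)cc3)CC2)cc1` differs from compound 2 in one place: cyano in place of methoxy on an aromatic carbon. Among the measured compounds shown here, the change sits on the aryl ring of the piperazine, a part of the molecule that no measured step touches. For the measured compounds named here, the step from compound 1 to compound 3 therefore does not bear on it, and no other pair in this assay reports on a substituent on that ring. With nothing to lean on, the expectation for this assay is a step of no clear size in either direction, that is, a number 2.7 percentage points higher from compound 2 to compound 4 (within the scatter) is expected to stay within the scatter.

On that basis compound 4 is estimated at 28%, in the range 15% to 42%.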

Compound 4, a percentage reported as inhibition, at one concentration (the size of the read-out at that concentration, not a potency): 34.5%
Compound 4: the middle estimate sits 6.5 percentage points below what was measured; the range from low to high includes it.
By their numbers in this assay, from the lowest: compounds 2, 3, 4 and 1 (each within the scatter of the next, the first and the last beyond it).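

In this assay, among these compounds, the change from 4-methoxyphenyl to 4-cyanophenyl gives the first reading on the aryl ring of the piperazine, and a number 9.2 percentage points higher from compound 2 to compound 4 (within the scatter) does not separate the two compounds, so no order is claimed between them. The earlier step reported only on the amine on the thiocarbonyl carbon, whereas this pair keeps that amine fixed and shows that, on an aromatic carbon para to a large group, exchanging methoxy for cyano does not move the read-out beyond the usual scatter. No measurement at hand bears on the reason for the size of this step.

Still open, going by these compounds, is whether in this assay another group at this place, such as an amine, a carboxylic acid or a trifluoromethyl, would move the read-out beyond the scatter, since two substituents cannot show a trend for the ring. The read-out also comes from a single concentration and is not a potency, so compound 2 and compound 4 could still differ across a full concentration series.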